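Methyl for isopropyl on the ring nitrogen of compound 1

The source may report more compounds than this note shows. Statements on the series, on what has been measured and on what is new or still open speak of the compounds shown alone.

Compound 1 `CC(C)n1nc(CN2CCCC2)nc1-c1ccc(C(C)(C)C)cc1` is the strongest inhibitor among the three measured compounds in an assay on membranes from Jurkat cells for displacement of a labelled ligand from Sigma non-opioid intracellular receptor 1 (Homo sapiens), read by scintillation counting, with a stated time of 2 h (a higher number here means a weaker inhibitor, a lower number a stronger inhibitor), giving 2.2 nM. Compound 2 `Cn1nc(CN2CCCC2)nc1-c1cccc(C(C)(C)C)c1` gives 29 nM in this assay, and compound 3 `Cn1nc(CN2CCCC2)nc1-c1ccc2cc(Cl)sc2c1` gives 37 nM; both lie beyond the scatter from compound 1. For the measured compounds named here, no pair of measured compounds differs in one place only, so no single step is isolated.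

Compound 4 `Cn1nc(CN2CCCC2)nc1-c1ccc(C(C)(C)C)cc1` is not yet measured. It differs from compound 1 as follows: methyl in place of isopropyl on an aromatic nitrogen. Compounds 2 and 3 each carry the methyl that enters here, but both differ from compound 4 in more than one place. Compound 2 gives 29 nM and compound 3 gives 37 nM; these values only hint that methyl-bearing analogues in this series sit above compound 1.

A modest loss is expected for compound 4 relative to compound 1, the step of a 3.2-fold higher number from compound 1 to compound 4 (0.50 log units; beyond the scatter) expected to be small and probably within the scatter. Compound 4 is estimated at 7 nM, with a range from 2 nM to 25 nM.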

Compound 4, inhibition constant: 7.5 nM
Compound 4: the middle estimate sits 1.1-fold (0.03 log units) below what was measured; low and high end bracket the measured number.
By their numbers in this assay, from the lowest: compound 1; then compound 4; then compounds 2 and 3 (each within the scatter of the next).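

Methyl for isopropyl on the aromatic nitrogen is the first single change isolated in this series. In this assay it gives a 3.4-fold higher number from compound 1 to compound 4 (0.53 log units; beyond the scatter), so the change at this position has a real but modest effect, and compound 4 with its methyl still gives 7.5 nM. Nothing measured here accounts for the size of this step.

With only methyl and isopropyl shown, it remains open how ethyl, cyclopropyl, a longer chain or a plain hydrogen on this nitrogen would compare, or whether a 2-hydroxyethyl chain would be accepted there. From the compounds shown here alone, it is also open whether the step keeps its size when the (pyrrolidin-1-yl)methyl group gives way to another amine, such as piperidine or morpholine.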